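Adding an Ethyl Group to Compound 2

A few compounds are considered here, and "the series" means these few. Any claim that something is new, unique, unknown or untested is made for them only; others in the source may bear on it.

Compound 2 `Cc1cn(-c2cc(NC(=O)c3cccc(Nc4nc(-c5cccnc5)cs4)c3)cc(C(F)(F)F)c2)cn1` gives 1720 nM in a functional assay on K562 cells (Homo sapiens) for antiproliferative activity; a higher number here means a weaker inhibitor, a lower number a stronger inhibitor. Within the data shown here, of the two numbers so far, that of compound 2 stands within the scatter of compound 1 `Cc1cn(-c2cc(NC(=O)c3ccc(C)c(Nc4nc(-c5cccnc5)cs4)c3)cc(C(F)(F)F)c2)cn1`, which in this assay gives 1830 nM; the step of a 1.1-fold lower number from compound 1 to compound 2 (0.03 log units; within the scatter) is small. Compound 3 `CCc1ccc(C(=O)Nc2cc(-n3cnc(C)c3)cc(C(F)(F)F)c2)cc1Nc1nc(-c2cccnc2)cs1` differs from compound 2 by ethyl in place of hydrogen on an aromatic carbon, on an aromatic carbon of a six-membered aromatic ring of carbon only, ortho to a (4-(pyridin-3-yl)-1,3-thiazol-2-yl)amino group. Among the measured compounds shown here, the one step that bears on it, a 1.1-fold lower number from compound 1 to compound 2 (0.03 log units; within the scatter), stayed within the scatter, so the expected step in this assay is a 1.0-fold lower number from compound 2 to compound 3 (0.01 log units; within the scatter), nothing beyond the scatter. Compound 3 is therefore estimated at 1700 nM, within 700 nM to 4200 nM.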

Compound 3, half-maximal inhibitory concentration: 2720 nM
Compound 3: the middle estimate sits 1.6-fold (0.20 log units) below what was measured; low and high end bracket the measured number.
By their numbers in this assay, from the lowest: compounds 2, 1 and 3 (each within the scatter of the next).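

At this position, ortho to a (4-(pyridin-3-yl)-1,3-thiazol-2-yl)amino group, ethyl is the largest group so far, and this assay still does not separate it from hydrogen (a 1.6-fold higher number from compound 2 to compound 3 (0.20 log units; within the scatter)) or from methyl (a 1.5-fold higher number from compound 1 to compound 3 (0.17 log units; within the scatter)). Hydrogen, methyl and ethyl thus give numbers within the scatter of one another, so this short series shows no trend with chain length. Nothing available explains these numbers.

Going by these compounds, a longer chain, an amine or a carboxylic acid at this position remains open. So does whether any group placed here can move the number beyond the scatter.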